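The compounds below may be only part of what the source reports. "The series", "measured", "known", "first", "only" and "open" are said of these compounds alone.

Going by the values given here, in a physicochemical assay for solubility, at pH 7.4 (on this read-out lower numbers stand for lower solubility and higher numbers for higher solubility), compound 2 `Cc1cccc(Nc2cc(C3CC3)c(C(=O)NCC3CCOCC3)cn2)c1` gives 26 ug/mL, the only true number so far. Compound 1 `O=C(NCC1CCOCC1)c1cnc(Nc2cccc(OC(F)(F)F)c2)cc1C1CC1` gives < 1 ug/mL, which is a limit of the assay and not a number. Among the compounds with values here, the one measured step is an at least 26-fold higher number from compound 1 to compound 2 (1.41 log units; beyond the scatter), with methyl in place of trifluoromethoxy on an aromatic carbon. It starts from a limit and concerns a different swap, so it fixes no size for the next change. Compound 3 `COc1cccc(Nc2cc(C3CC3)c(C(=O)NCC3CCOCC3)cn2)c1` differs by methoxy in place of methyl on an aromatic carbon, with methoxy in place of methyl on an aromatic carbon. The expected step is a 1.3-fold lower number from compound 2 to compound 3 (0.11 log units; within the scatter), none beyond the scatter. Compound 3 is estimated at 20 ug/mL, with an expected range of 6 ug/mL to 60 ug/mL.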

Compound 3, solubility: 168 ug/mL
Estimate against measurement, compound 3: 8.4-fold (0.92 log units) below; measured number outside the range, above it.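

In this assay, this place on the aromatic ring, meta to a large group, responds to more than the loss of trifluoromethoxy, since a swap between two small groups also moves the read-out: a 6.5-fold higher number from compound 2 to compound 3 (0.81 log units; beyond the scatter). Keeping the oxygen and putting methyl in place of trifluoromethyl gives an at least 160-fold higher number from compound 1 to compound 3 (2.22 log units; beyond the scatter), so among these compounds an oxygen at this place does not by itself go with a low number. Compound 1 stands at a limit of the assay, not a number: the limit of < 1 ug/mL in this assay, at which 1 of the 3 values shown sits.

On these data alone, how an amine, a hydroxyl or a chlorine at this place would read remains open. So does whether methoxy elsewhere on the ring would give a similar step.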